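A few compounds are considered here, and "the series" means these few. Any claim that something is new, unique, unknown or untested is made for them only; others in the source may bear on it.

Measured compounds and their values:

Compound 1, `Oc1cccc2ccc(Sc3ccccn3)nc12`: 20900 nM
Compound 2, `Oc1ccc(Cl)c2ccc(Sc3ccccn3)nc12`: 10200 nM
Compound 3, `Oc1cccc2ccc(Oc3ccccn3)nc12`: > 30000 nM

All three were tested in a functional assay on PC-3 cells (Homo sapiens) for antiproliferative activity, read by MTT assay, with a stated time of 96 h; a lower number here means a stronger inhibitor of growth, a higher number a weaker inhibitor of growth. Compound 1, with the structure `Oc1cccc2ccc(Sc3ccccn3)nc12`, gives 20900 nM in this assay. Compound 2, `Oc1ccc(Cl)c2ccc(Sc3ccccn3)nc12`, carries one change against compound 1: chloro in place of hydrogen on an aromatic carbon. That change brought a 2.0-fold lower number from compound 1 to compound 2 (0.31 log units; beyond the scatter). Compound 3, `Oc1cccc2ccc(Oc3ccccn3)nc12`, has a different core; how the core of compound 3 differs from the core of compound 1 is not broken down here. For compound 3 this assay gives only a limit, > 30000 nM, and not a number. This is the assay's own limit, (the limit of > 30000 nM in this assay, at which 1 of the 3 values shown sits).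

Compound 4, `Oc1ccc(Cl)c2ccc(Oc3ccccn3)nc12`, has not yet been measured. It stands to compound 3 as compound 2 stands to compound 1: chloro in place of hydrogen on an aromatic carbon. The two changes are described in the same words at the same kind of place, so they can be called the same change, made once in each core.

For the measured compounds named here, for compound 4 the expected step is an at least 1.2-fold lower number from compound 3 to compound 4 (0.07 log units; that floor lies within the scatter), resting on the only measured example of this change, which gave a 2.0-fold lower number from compound 1 to compound 2 (0.31 log units; beyond the scatter). Because compound 3 shows only the limit > 30000 nM, the starting point for compound 4 is itself uncertain, and a number for compound 4 is expected to sit around 25000 nM, plausibly anywhere from 10000 nM to 60000 nM, with a real chance that this assay again reports only a limit for compound 4.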

Compound 4, concentration for 50% growth inhibition: > 30000 nM
Compound 4 gave a limit, no number; the forecaster's own chance of this, stated with the estimate: 50%; at least 1.2-fold (0.07 log units) between middle value and limit.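

In this assay, compound 3 and compound 4 each give only a limit and not a number, so no step can be read from compound 3 to compound 4: the limit of > 30000 nM in this assay, at which 2 of the 4 values shown sit.

The compounds shown leave open what chloro in place of hydrogen does in this core, and whether its effect there comes close to a 2.0-fold lower number from compound 1 to compound 2 (0.31 log units; beyond the scatter).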